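Swapping Methoxy for Amino on a Sulfonamide

This account rests on a few compounds, and the source may have more. Where it says the series, first, only, none or still open, it means among the compounds named here.

compound 1 `COc1ccc(S(=O)(=O)Nc2cccc3cc[nH]c23)cc1`: 1.5 ug/mL
compound 2 `O=S(=O)(Nc1cccc2cc[nH]c12)c1ccc(Cl)cc1`: 7 ug/mL
compound 3 `N#Cc1ccc(S(=O)(=O)Nc2cccc3cc[nH]c23)cc1`: 1.8 ug/mL

In a functional assay on MC-38 cells (Mus musculus) for antiproliferative activity (a higher number here means a weaker inhibitor, a lower number a stronger inhibitor), compound 1 sits at the low end of these numbers, together with compound 3. The gap between them is small: a 1.2-fold higher number from compound 1 to compound 3 (0.08 log units; within the scatter). Only compound 2 stands clearly apart, with a 4.7-fold higher number from compound 1 to compound 2 (0.67 log units; beyond the scatter).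

The untested compound 4 `Nc1ccc(S(=O)(=O)Nc2cccc3cc[nH]c23)cc1` keeps the core of compound 1 and changes one group: amino in place of methoxy on an aromatic carbon. Here amino replaces methoxy on an aromatic carbon, para to a large group. Among the measured compounds shown here, no amino compound has been measured yet, so the only guides are the two other replacements of methoxy. Cyano made no difference beyond the scatter, while chloro gave a modest step. A small step is therefore the reasonable expectation, with a slightly higher number more likely than a lower one. The estimated step is a 1.7-fold higher number from compound 1 to compound 4 (0.22 log units; within the scatter). For compound 4, the expected value is 2.5 ug/mL, with an estimated range of 0.8 ug/mL to 8 ug/mL.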

Compound 4, half-maximal inhibitory concentration: 6.1 ug/mL
For compound 4 the middle estimate is 2.4-fold (0.39 log units) below the measured one; the range from low to high includes it.
By their numbers in this assay, from the lowest: compounds 1 and 3 (each within the scatter of the next); then compounds 4 and 2 (each within the scatter of the next).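

In this assay the step of a 4.1-fold higher number from compound 1 to compound 4 (0.61 log units; beyond the scatter) makes amino the second replacement of methoxy, after chloro, to move beyond the scatter, so cyano is now the only one of the three that stays level with methoxy. The step of a 3.4-fold higher number from compound 3 to compound 4 (0.53 log units; beyond the scatter) shows that the choice of group on this aromatic carbon, para to a large group, matters, while the step of a 1.1-fold lower number from compound 2 to compound 4 (0.06 log units; within the scatter) places amino and chloro together. The four compounds therefore form two levels, with methoxy and cyano at the lower numbers and amino and chloro at the higher ones.

No measured property is available to explain this split. As far as these compounds go, whether a hydroxy group or a dimethylamino group in this place would join the lower or the higher level remains open.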